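Removing the sulfonyl group from the seven-membered ring nitrogen

The source may report more compounds than this note shows. Statements on the series, on what has been measured and on what is new or still open speak of the compounds shown alone.

Two compounds of this series have numbers in a functional assay on MCF7 cells (Homo sapiens) for antiproliferative activity; a higher number here means a weaker inhibitor, a lower number a stronger inhibitor. Compound 1, `COc1ccc2c(c1)COC(n1cc(F)c(=O)[nH]c1=O)CO2`, gives 1250 nM. Compound 2, `O=[N+]([O-])c1ccccc1S(=O)(=O)N1CC(n2cnc3ncnc(Sc4ccccc4)c32)OCc2ccccc21`, gives 2590 nM; this is the highest of the two numbers, and the gap to compound 1 lies beyond the usual scatter, so compound 2 is the weaker of the two.

Compound 3, `c1ccc(Sc2ncnc3ncn(C4CNc5ccccc5CO4)c23)cc1`, is not yet measured. It differs from compound 2 in one place: hydrogen in place of (2-nitrophenyl)sulfonyl on a nitrogen on an aromatic ring in a ring. The shared core of compound 2 and compound 3 is otherwise unchanged.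

Among the compounds with values here, no step between measured compounds bears on this change, so the expectation rests on the size of the group that leaves alone. A group of this size is removed with nothing put in its place, and a step beyond the scatter in either direction is plausible; on balance a moderate move towards a higher number is expected, the step from compound 2 to compound 3 being estimated at a 1.5-fold higher number from compound 2 to compound 3 (0.19 log units; within the scatter). Compound 3 is therefore expected to give about 4000 nM, within a range from 1200 nM to 14000 nM.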

Compound 3, half-maximal inhibitory concentration: 48900 nM
For compound 3 the middle estimate is 12-fold (1.09 log units) below the measured one, and the stated range ends below it.
By their numbers in this assay, from the lowest: compound 1; then compound 2; then compound 3.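

Replacing (2-nitrophenyl)sulfonyl with hydrogen on the nitrogen of the seven-membered ring gives a 19-fold higher number from compound 2 to compound 3 (1.28 log units; beyond the scatter) in this assay, so this position is far from indifferent to what it carries. Within the data shown here, this is the first step that changes a single place, and it sets compound 2, with the intact (2-nitrophenyl)sulfonyl group, clearly ahead of compound 3, with the free nitrogen, while the rest of the shared core stays the same. Nothing available on these compounds accounts for the size of this step, so it stands as an observed difference without an explanation.

The step removes the sulfonyl link and the 2-nitrophenyl ring together, so their separate contributions remain unresolved; a methanesulfonyl group, an unsubstituted phenylsulfonyl group or an acetyl group on the same nitrogen would help to distinguish them. Also open, as far as these compounds go, is whether the nitro group itself matters, which a comparison with a 2-methoxyphenylsulfonyl or 4-nitrophenylsulfonyl group on this nitrogen would address.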